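Widening the Ring at the Chain Carbon

The source may report more compounds than this note shows. Statements on the series, on what has been measured and on what is new or still open speak of the compounds shown alone.

Of the compounds shown here, three built on one shared core have been measured in an in vitro functional assay on cells for agonist activity at Bombesin receptor subtype-3 (Homo sapiens), read by luminescence and calcium flux; on this read-out higher numbers stand for an effect only at larger amounts of compound and lower numbers for an effect already at smaller amounts. Compound 1 `Cc1cccc(Cc2cnc(CCc3ccc(-c4ccccc4C(=O)O)cc3)[nH]2)c1` carries a 3-methylphenyl group on a saturated chain carbon bound to an aromatic carbon and gives 4310 nM. Compound 2 `O=C(O)c1ccccc1-c1ccc(CCc2ncc(Cc3cccc(F)c3)[nH]2)cc1` carries a 3-fluorophenyl group at that place and gives 159 nM. Compound 3 `O=C(O)c1ccccc1-c1ccc(CCc2ncc(CC3CC3)[nH]2)cc1` carries a cyclopropyl group there and gives 1000 nM, which places it second highest of the three numbers: a 4.3-fold lower number from compound 1 to compound 3 (0.63 log units; beyond the scatter), while a 6.3-fold higher number from compound 2 to compound 3 (0.80 log units; beyond the scatter).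

Compound 4 `O=C(O)c1ccccc1-c1ccc(CCc2ncc(CC3CCCCCC3)[nH]2)cc1` has not yet been measured. It differs from compound 3 in one place only: cycloheptyl in place of cyclopropyl on a saturated chain carbon bound to an aromatic carbon.

The two measured steps that touch this place each swapped an aromatic ring for cyclopropyl, and each moved the number by a modest amount, in opposite directions. No measured step compares one saturated ring with a larger saturated ring, so the change from cyclopropyl to cycloheptyl has no direct precedent among these compounds. This place has so far tolerated groups of different kinds within a modest span. A small step is expected, a 1.7-fold lower number from compound 3 to compound 4 (0.22 log units; within the scatter), and the uncertainty is wide. Compound 4 is estimated at 600 nM, with a range from 150 nM to 3000 nM.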

Compound 4, half-maximal effective concentration: 88 nM
Estimate against measurement, compound 4: 6.8-fold (0.83 log units) above; measured number outside the range, below it.
By their numbers in this assay, from the lowest: compounds 4 and 2 (each within the scatter of the next); then compound 3; then compound 1.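

Enlarging the saturated ring from a three-membered to a seven-membered one at this place in this assay gives an 11-fold lower number from compound 3 to compound 4 (1.06 log units; beyond the scatter) without adding any hydrogen-bond donor or acceptor, so the size of a carbon-only ring can matter a great deal here. An aromatic ring is also not required at this place: a 1.8-fold lower number from compound 2 to compound 4 (0.26 log units; within the scatter) is a step that leaves cycloheptyl and 3-fluorophenyl indistinguishable on this read-out, while a 49-fold lower number from compound 1 to compound 4 (1.69 log units; beyond the scatter) sets cycloheptyl well apart from 3-methylphenyl. Nothing available here explains why the larger ring has this effect.

Going by these compounds, with only a three-membered and a seven-membered saturated ring in hand, it remains open whether the number falls steadily as the ring grows or changes abruptly at some size, which cyclobutyl, cyclopentyl and cyclohexyl would help to settle. On these data alone, it is also open whether a ring is needed at all, a question for a longer open chain such as hexyl, and whether the ring must be carbon only, a question for a piperidine ring carrying an amine.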